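A few compounds are considered here, and "the series" means these few. Any claim that something is new, unique, unknown or untested is made for them only; others in the source may bear on it.

The measured compounds:
Compound 1 `COc1ccc(OC(=O)c2cn(-c3ccccc3)nc2-c2cccnc2)cc1` gives in a functional assay on Raji cells (Homo sapiens) for cytotoxicity, read by MTT assay, with a stated time of 48 h (on this read-out higher numbers stand for weaker inhibition and lower numbers for stronger inhibition), only a limit, > 100000 nM.
Compound 2 `Cc1ccc(C(C)C)c(OC(=O)c2cn(-c3ccccc3)nc2-c2cccnc2)c1` gives in this assay 20600 nM.
Compound 3 `O=C(Oc1ccc(-c2ccccc2)cc1)c1cn(-c2ccccc2)nc1-c1cccnc1` has no result in this assay, recorded as "nd(insoluble)" (no result reported).

Compound 1 thus stands at the upper edge of what this assay reports: its value is a limit, not a number, and it is the one entry that sits at the limit of > 100000 nM in this assay, at which 1 of the 3 values shown sits. The one measured step among these compounds is an at least 4.8-fold lower number from compound 1 to compound 2 (0.68 log units; beyond the scatter), which is beyond the scatter and arises from exchanging the aryl group on the oxygen next to the carbonyl group.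

Compound 4 `COc1ccc(OC(=O)c2cn(-c3ccccc3)nc2-c2ccncc2)cc1` has the same atoms as compound 1 joined differently: pyridin-4-yl in place of pyridin-3-yl on an aromatic carbon. That change sits on the five-membered ring, not on the ester oxygen, so the step from compound 1 to compound 2 does not bear on it. Within the data shown here, no measured step touches the pyridyl group at all. With compound 1 at a limit and no evidence that moving the ring nitrogen shifts potency, compound 4 is expected to remain near that limit, with an estimated step of a number no higher from compound 1 to compound 4 (the limit leaves the size open) that lies within the scatter. The estimate for compound 4 in this assay is 100000 nM, expected to fall between 30000 nM and 300000 nM.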

Compound 4, half-maximal inhibitory concentration: > 100000 nM
Compound 4 gave a limit, no number; the forecaster's own chance of this, stated with the estimate: 60%; the middle value lies on the limit itself.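

Among these compounds, compound 4, like compound 1, gives only a limit and not a number in this assay, so no step between compound 1 and compound 4 can be read: the limit of > 100000 nM in this assay, at which 2 of the 4 values shown sit.

The compounds shown leave open whether pyridin-4-yl in place of pyridin-3-yl changes the result when the compound gives a number rather than a limit.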